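This account rests on a few compounds, and the source may have more. Where it says the series, first, only, none or still open, it means among the compounds named here.

Measured compounds:
compound 1 `Cc1nc2c3ccccc3ccc2c2nc3c(ccc4ccccc43)c(C)c12`: in a functional assay on AGS cells (Homo sapiens) for cytotoxicity, read by MTT assay, with a stated time of 48 h (on this read-out higher numbers stand for weaker inhibition and lower numbers for stronger inhibition), compound 1 gives only the assay limit > 80000 nM.
compound 2 `Cc1nc2c3ccccc3ccc2c2nc3c(ccc4ccccc43)c(-c3ccc(O)cc3)c12`: in this assay compound 2 gives 14200 nM.

Compound 1 stands only as a limit in this assay, with no number of its own (the limit of > 80000 nM in this assay, at which 1 of the 2 values shown sits). Compound 3 `Cc1nc2c3ccccc3ccc2c2nc3c(ccc4ccccc43)c(-c3cccnc3)c12` is not yet measured; it differs from compound 1 by pyridin-3-yl in place of methyl on an aromatic carbon. For the measured compounds named here, the one measured step that bears on this change is an at least 5.6-fold lower number from compound 1 to compound 2 (0.75 log units; beyond the scatter), where an aromatic ring likewise replaced the methyl on the core, and that step is beyond the scatter. Compound 3 carries a pyridin-3-yl rather than the 4-hydroxyphenyl of compound 2, so the same direction is expected but with a smaller and less certain size. For compound 3 a lower number than compound 1 is expected in this assay, as an at least 2.6-fold lower number from compound 1 to compound 3 (0.42 log units; beyond the scatter). Compound 3 is estimated at 30000 nM, with a range from 10000 nM to 80000 nM. Because compound 1 itself sits at the limit (the limit of > 80000 nM in this assay, at which 1 of the 2 values shown sits), the outcome for compound 3 may also be reported only as a limit rather than as a number.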

Compound 3, half-maximal inhibitory concentration: 3960 nM
Estimate against measurement, compound 3: 7.6-fold (0.88 log units) above, and the stated range ends above it.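

In this assay, the lower number seen with an aromatic ring on this carbon, opposite the ring nitrogen, no longer rests on 4-hydroxyphenyl alone: pyridin-3-yl in place of methyl gives an at least 20-fold lower number from compound 1 to compound 3 (1.30 log units; beyond the scatter). The identity of the aromatic ring also matters at this position, since pyridin-3-yl in place of 4-hydroxyphenyl gives a 3.6-fold lower number from compound 2 to compound 3 (0.55 log units; beyond the scatter), and a hydroxyl group is therefore not needed for a lower number on this core. The step from the methyl compound can be read only as a lower bound on its size, since compound 1 gives a limit and no number of its own: the limit of > 80000 nM in this assay, at which 1 of the 3 values shown sits.

As far as these compounds go, whether a plain phenyl or a pyridin-4-yl would give a number close to that of compound 3 stays open, so the effect of the ring nitrogen cannot yet be separated from the loss of the hydroxyl group. Also open is whether a non-aromatic group on this carbon, such as an amine or a longer alkyl chain, would lower the number, and whether the order of these compounds holds in any other cell line.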